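Estimating a 4-acetylphenyl swap at the sulfonyl sulfur

The source may report more compounds than this note shows. Statements on the series, on what has been measured and on what is new or still open speak of the compounds shown alone.

- compound 1 `Cc1ccc(S(=O)(=O)NC(C2=CC(=O)c3c(O)ccc(O)c3C2=O)C(C)C)cc1`: "not determined" (no result reported)
- compound 2 `CC(C)C(NS(=O)(=O)c1cccc(Br)c1)C1=CC(=O)c2c(O)ccc(O)c2C1=O`: 790 nM
- compound 3 `CC(C)C(NS(=O)(=O)c1ccccc1Br)C1=CC(=O)c2c(O)ccc(O)c2C1=O`: 340 nM
- compound 4 `CC(=O)c1ccc(S(=O)(=O)NC(C2=CC(=O)c3c(O)ccc(O)c3C2=O)C(C)C)cc1`: not yet measured

These compounds share one core and differ in the group on the sulfonyl sulfur. In a functional assay on HL-60 cells (Homo sapiens) for cytotoxicity, read by MTT assay (on this read-out lower numbers stand for stronger inhibition and higher numbers for weaker inhibition), compound 3 gives 340 nM, the lower of the two numbers available. Compound 1 has no reported number, so it offers no guide.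

Compound 4 carries 4-acetylphenyl in place of 2-bromophenyl on a sulfonyl sulfur. Going by the values given here, only one measured step bears on this position, a 2.3-fold lower number from compound 2 to compound 3 (0.37 log units; beyond the scatter). That modest step, just beyond the scatter, came from exchanging 3-bromophenyl for 2-bromophenyl. Among the compounds with values here, no measured compound carries the acetyl group, so the data give only a loose guide. Compound 3 also holds the lower of the two numbers, so leaving its group is expected to raise the number modestly, towards the level of compound 2 at 790 nM.

The expected change is a 2.1-fold higher number from compound 3 to compound 4 (0.31 log units; beyond the scatter). The estimate for compound 4 is 700 nM, with an expected range from 250 nM to 2000 nM.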

Compound 4, half-maximal inhibitory concentration: 110 nM
Beside the measured number, compound 4's estimate is 6.4-fold (0.80 log units) above it; measured number below the stated range.
By their numbers in this assay, from the lowest: compound 4; then compound 3; then compound 2.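

In this assay the swap to 4-acetylphenyl on the sulfonyl sulfur gives a 3.1-fold lower number from compound 3 to compound 4 (0.49 log units; beyond the scatter) and a 7.2-fold lower number from compound 2 to compound 4 (0.86 log units; beyond the scatter) in one series, so a low number at this position does not depend on bromine. Compound 4 now has the lowest number of the three, and both of its steps lie beyond the scatter, which shows that this position can take a group with a hydrogen-bond acceptor, something neither bromophenyl group has. Nothing available explains this drop in the number.

The swap changes both the group and its place on the ring, so a 4-bromophenyl or a 3-acetylphenyl group would be needed to separate these two changes. As far as these compounds go, it also remains open how an amine or a carboxylic acid in place of the acetyl group would read out.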